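Benzylsulfanyl in Place of the Eight-Membered Ring

The source may report more compounds than this note shows. Statements on the series, on what has been measured and on what is new or still open speak of the compounds shown alone.

Compound 1 `CCCCN(C)c1cc(C(F)(F)F)ccc1CNC(=O)C(C)c1ccc(NS(C)(=O)=O)c(F)c1` gives 1.2 nM in an assay on CHO cells for antagonist activity at transient receptor potential cation channel subfamily V member 1 (Homo sapiens), read by FLIPR; on this read-out higher numbers stand for weaker inhibition and lower numbers for stronger inhibition.
Compound 2 `CC(C(=O)NCc1ccc(C(F)(F)F)cc1N1CCCCCCC1)c1ccc(NS(C)(=O)=O)c(F)c1` gives 2.8 nM in this assay.
Compound 3 `CC(C(=O)NCc1ccc(C(F)(F)F)cc1N1CCC(C)(C)CC1)c1ccc(NS(C)(=O)=O)c(F)c1` gives 1.3 nM in this assay.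

Compound 2 has the highest number of the three, with a 2.2-fold lower number from compound 2 to compound 3 (0.33 log units; beyond the scatter) and a 2.3-fold higher number from compound 1 to compound 2 (0.37 log units; beyond the scatter) marking its distance from the other two. Compound 4 `CC(C(=O)NCc1ccc(C(F)(F)F)cc1SCc1ccccc1)c1ccc(NS(C)(=O)=O)c(F)c1` differs from compound 2 by a group of 8 heavy atoms (7 carbon, 1 sulfur; one six-membered aromatic ring of carbon only) in place of a group of 8 heavy atoms (7 carbon, 1 nitrogen; one eight-membered non-aromatic ring with 1 hetero atom), on an aromatic carbon. Within the data shown here, no measured step carries a benzylsulfanyl group; the steps that bear on this position, a 2.3-fold higher number from compound 1 to compound 2 (0.37 log units; beyond the scatter) and a 2.2-fold lower number from compound 2 to compound 3 (0.33 log units; beyond the scatter), are both modest, so the group there has so far moved the number only a little. Compound 4 is therefore expected to land near compound 2, with a step of a 1.4-fold higher number from compound 2 to compound 4 (0.15 log units; within the scatter). The estimate for compound 4 is 4 nM, in the range 1.2 nM to 15 nM.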

Compound 4, inhibition constant: 0.5 nM
Compound 4: the middle estimate sits 8.0-fold (0.90 log units) above what was measured; measured number below the stated range.
By their numbers in this assay, from the lowest: compound 4; then compounds 1 and 3 (each within the scatter of the next); then compound 2.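

Benzylsulfanyl on this aromatic carbon gives the lowest number of the four in this assay: it stands beyond the scatter against each of the others (a 5.6-fold lower number from compound 2 to compound 4 (0.75 log units; beyond the scatter)), (a 2.6-fold lower number from compound 3 to compound 4 (0.41 log units; beyond the scatter)) and (a 2.4-fold lower number from compound 1 to compound 4 (0.38 log units; beyond the scatter)). Until now only groups joined through nitrogen had stood here, and a group joined through sulfur and carrying an aromatic ring lowers the number further still. No measurement shown gives a reason for this drop.
Whether the sulfur or the aromatic ring accounts for the step stays open. Benzyloxy, benzylamino and methylsulfanyl at this position would separate the two.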